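The compounds below may be only part of what the source reports. "The series", "measured", "known", "first", "only" and "open" are said of these compounds alone.

Measured so far: compound 1 `CCN(CC)CCNC(=O)c1ccc(C(CC)(CC)c2ccc(OCC(O)C(C)(C)C)c(C)c2)n1CC`, 690 nM; compound 3 `CCn1c(C(=O)NCCN)ccc1C(CC)(CC)c1ccc(OCC(O)C(C)(C)C)c(C)c1`, 5.9 nM; compound 2 `CCn1c(C(=O)NCC(OC)OC)ccc1C(CC)(CC)c1ccc(OCC(O)C(C)(C)C)c(C)c1`, for which > 50000 nM is a limit of the assay, not a number.

In a functional assay on MCF7 cells (Homo sapiens), read by MTT assay, with a stated time of 48 h (a higher number here means a weaker inhibitor, a lower number a stronger inhibitor), compound 1 stands highest of the two numbers shown, with compound 3 the nearest, a 120-fold lower number from compound 1 to compound 3 (2.07 log units; beyond the scatter). The step from compound 1 to compound 2, dimethoxymethyl in place of (diethylamino)methyl, ran the other way, an at least 72-fold higher number from compound 1 to compound 2 (1.86 log units; beyond the scatter), ending at the limit (the limit of > 50000 nM in this assay, at which 1 of the 3 values shown sits).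

Compound 4 `CCn1c(C(=O)N(CCC#N)CCC#N)ccc1C(CC)(CC)c1ccc(OCC(O)C(C)(C)C)c(C)c1` is not yet measured. Relative to compound 1 the change is a group of 9 heavy atoms (6 carbon, 3 nitrogen; no ring) in place of a group of 8 heavy atoms (6 carbon, 2 nitrogen; no ring), on a carbonyl carbon. Both measured steps bear on it: in this series the amino-bearing chain is kept or strengthened in compound 3 and removed in compound 2, and compound 4 follows the latter, with no hydrogen-bond donor remaining on the entering group. A large rise in number, as for compound 2, is expected, with a fair chance that only a limit is reported. Compound 4 is therefore estimated at 30000 nM, range 5000 nM to 150000 nM, an expected step of a 43-fold higher number from compound 1 to compound 4 (1.64 log units; beyond the scatter).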

Compound 4, half-maximal inhibitory concentration: 480 nM
Compound 4: the middle estimate sits 63-fold (1.80 log units) above what was measured; the whole stated range lies above it.
By their numbers in this assay, from the lowest: compound 3; then compounds 4 and 1 (each within the scatter of the next). At a limit, above all of these: compound 2.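

In this assay the step on the carbonyl carbon is a 1.4-fold lower number from compound 1 to compound 4 (0.16 log units; within the scatter) and so lies within the scatter, which shows that a value at this level survives the loss of both the (2-(diethylamino)ethyl)amino group and the amide hydrogen. The step of an 81-fold higher number from compound 3 to compound 4 (1.91 log units; beyond the scatter) shows that the nitrile-bearing group does not reach the level of the short amino chain of compound 3. Compound 2 is held at a limit of the assay, not a number, and the step of an at least 100-fold lower number from compound 2 to compound 4 (2.01 log units; beyond the scatter) shows that an entering group without an amine need not end at that limit.

Open, as far as these compounds go, is whether compound 3 owes its value to the primary amine or to the short chain, which a 3-aminopropyl chain or a methylamino end would test. Also open, from the compounds shown here alone, is whether the nitrile matters, which plain propyl chains on the amide nitrogen would test.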